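This account rests on a few compounds, and the source may have more. Where it says the series, first, only, none or still open, it means among the compounds named here.

Compound 1 `C/C(C(=O)NC1CC1)=C(/C)c1ccc(Br)cc1`: 130 mg/kg
Compound 2 `C=CCNC(=O)/C(C)=C(/C)c1ccc(C)cc1`: 400 mg/kg
Compound 3 `C/C(C(=O)NC1CC1)=C(/C)c1ccc(F)cc1`: 70 mg/kg

These three numbers all come from a toxicity assay on the whole organism (strain Icem-CET (SPF Caw)) for cytotoxicity, with Mus musculus as the target; on this read-out higher numbers stand for an effect only at larger amounts of compound and lower numbers for an effect already at smaller amounts. Compound 3 holds the lowest of the three. Its nearest neighbour is compound 1, and the step of a 1.9-fold lower number from compound 1 to compound 3 (0.27 log units; within the scatter) stays within the scatter, so the two cannot be ranked against each other. The gap between compound 3 and compound 2, by contrast, lies beyond the scatter.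

Compound 4 `C#CCNC(=O)/C(C)=C(\C)c1ccc(F)cc1` has not yet been measured in this assay. It differs from compound 3 in one place: propargyl in place of cyclopropyl on an amide-type nitrogen. The only measured step among these compounds, a 1.9-fold lower number from compound 1 to compound 3 (0.27 log units; within the scatter), concerns the exchange of one halogen for another on an aromatic carbon and says nothing about the group on the amide nitrogen. Compound 2 does carry a different group on that nitrogen and shows a higher number, but it also differs from compound 3 elsewhere, so that pair gives no clean reading. Going by the values given here, with no measured step bearing directly on the exchange of cyclopropyl for propargyl, the expected step of a 1.4-fold higher number from compound 3 to compound 4 (0.15 log units; within the scatter) is one of no change beyond the scatter, held with wide uncertainty. For compound 4 the estimated value in this assay is 100 mg/kg, with a range from 40 mg/kg to 250 mg/kg.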

Compound 4, dose for half-maximal effect: 100 mg/kg
Compound 4: the middle estimate sits on the measured number at the digits printed; low and high end bracket the measured number.
By their numbers in this assay, from the lowest: compounds 3, 4 and 1 (each within the scatter of the next); then compound 2.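

Going by these compounds alone, with a 1.4-fold higher number from compound 3 to compound 4 (0.15 log units; within the scatter) in this assay, the group on the amide-type nitrogen can be read in a clean pair for the first time, since the earlier measured step concerned only the halogen on the aromatic carbon. Cyclopropyl and propargyl each bring three carbons, but one closes them into a three-membered ring and the other holds them in an open chain with a triple bond, and this read-out cannot rank the two compounds against each other. For this pair, then, the ring is not needed to keep the number within the scatter, and nothing available explains why the exchange is tolerated.

The compounds shown leave open whether this tolerance extends to a longer chain, or to a group of a different kind on that nitrogen, such as an amine or a carboxylic acid. They also leave open whether propargyl and cyclopropyl would read alike on the bromo core of compound 1, as this exchange is shown only with fluoro on the aromatic carbon.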